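The source may report more compounds than this note shows. Statements on the series, on what has been measured and on what is new or still open speak of the compounds shown alone.

Of the compounds shown here, two built on one shared core have been measured in a functional assay on MGC-803 cells (Homo sapiens) for inhibition, read by MTT assay, with a stated time of 72 h; a lower number here means a stronger inhibitor, a higher number a weaker inhibitor. Compound 1 `C#CCSc1nc(Nc2ccc(F)cc2)c2ccncc2n1` carries a 4-fluorophenyl on a nitrogen on an aromatic ring, and in this assay compound 1 gives 15800 nM. Compound 2 `C#CCSc1nc(Nc2cccc(Cl)c2)c2ccncc2n1` carries a 3-chlorophenyl in that place, and in this assay compound 2 gives 2190 nM, the lower of the two numbers. Among the compounds with values here, the single step seen so far is a 7.2-fold lower number from compound 1 to compound 2 (0.86 log units; beyond the scatter), a modest one. Compound 3 `C#CCSc1nc(Nc2ccc(Br)cc2)c2ccncc2n1` is not yet measured; its change from compound 2 is 4-bromophenyl in place of 3-chlorophenyl on a nitrogen on an aromatic ring. Within the data shown here, the entering 4-bromophenyl shares its substitution pattern with the 4-fluorophenyl of compound 1 but carries bromine rather than fluorine, so no measured step matches this change exactly. Among the measured compounds shown here, with the step from compound 1 to compound 2 as the only guide, a number between the two measured values is expected for compound 3, meaning an estimated step of a 2.3-fold higher number from compound 2 to compound 3 (0.36 log units; beyond the scatter). The estimate for compound 3 in this assay is 5000 nM, expected to fall between 1500 nM and 16000 nM.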

Compound 3, half-maximal inhibitory concentration: 26000 nM
Beside the measured number, compound 3's estimate is 5.2-fold (0.72 log units) below it, and the stated range ends below it.
By their numbers in this assay, from the lowest: compound 2; then compounds 1 and 3 (each within the scatter of the next).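

In this assay there is a 1.6-fold higher number from compound 1 to compound 3 (0.22 log units; within the scatter), so bromo in place of fluoro on the aromatic carbon does not separate these two compounds. By contrast, there is a 12-fold higher number from compound 2 to compound 3 (1.07 log units; beyond the scatter), which shows that this group on the nitrogen can matter a great deal, with the 3-chlorophenyl of compound 2 standing apart from both 4-substituted phenyl groups among these three compounds. No measurement available here explains this difference.

The step to compound 3 changes both the halogen and its place on the ring, so a 4-chlorophenyl or a 3-bromophenyl group would be needed to show which change carries the effect. Going by these compounds, how a phenyl ring bearing an amine or a carboxylic acid would behave here also remains open.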